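Moving the Fluorine on the Phenyl Ring

The source may hold more compounds than are shown below. What is called first, only, known or untested is meant among the compounds shown, and "the series" means these compounds.

Compound 2 `O=c1[nH]cc(S(=O)(=O)Nc2ccccc2-c2cn(-c3ccccc3F)nn2)c(=O)[nH]1` gives > 100000 nM in an ADME assay on L02 cells (Homo sapiens) for cytotoxicity, read by MTT assay, with a stated time of 24 h (on this read-out higher numbers stand for lower toxicity in this test and lower numbers for higher toxicity in this test), and this is a limit of the test rather than a number. Compound 1 `Cc1ccccc1-n1cc(-c2ccccc2NS(=O)(=O)c2c[nH]c(=O)[nH]c2=O)nn1` gives 56600 nM. Going by the values given here, the only measured step, an at least 1.7-fold higher number from compound 1 to compound 2 (0.24 log units; that floor lies within the scatter), ends at the limit of > 100000 nM in this assay, at which 1 of the 2 values shown sits. Compound 3 `O=c1[nH]cc(S(=O)(=O)Nc2ccccc2-c2cn(-c3cccc(F)c3)nn2)c(=O)[nH]1` carries 3-fluorophenyl in place of 2-fluorophenyl on an aromatic nitrogen. No measured step shifts the fluorine on this ring, and the one step shown lies within the scatter, so the step that the limit leaves unreadable from compound 2 to compound 3 is expected to stay within the scatter as well. Compound 3 is therefore expected near 120000 nM, between 50000 nM and 300000 nM.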

Compound 3, half-maximal cytotoxic concentration: "not toxic" (no number reported)
For compound 3 the study gives words and no number; the estimate stays without a comparison.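

No step can be read from compound 2 to compound 3: compound 3 is reported only in words, as not toxic, and compound 2 only as a limit. Going by these compounds, whether moving the fluorine shifts the toxicity reading at all stays open.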